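Methyl for Isopropyl on a Chloro Oxindole Analogue

The source may hold more compounds than are shown below. What is called first, only, known or untested is meant among the compounds shown, and "the series" means these compounds.

Of the compounds shown here, three built on one shared core have been measured in a functional assay on 4T1 cells (Homo sapiens) for cytotoxicity, read by MTT assay, with a stated time of 48 h; on this read-out higher numbers stand for weaker inhibition and lower numbers for stronger inhibition. Compound 1 `CC(C)n1c(/C=C2/C(=O)Nc3ccc(Br)cc32)nc2ccccc21` gives 5960 nM in this assay. Compound 2 `Cn1c(/C=C2/C(=O)Nc3ccc(Br)cc32)nc2ccccc21` carries a methyl where compound 1 carries an isopropyl, the change being (methyl in place of isopropyl on an aromatic nitrogen). In this assay compound 2 reaches only the limit of > 50000 nM, which is a limit of the assay and not a number. That change produced an at least 8.3-fold higher number from compound 1 to compound 2 (0.92 log units; beyond the scatter), a step that sits at the limit of > 50000 nM in this assay, at which 1 of the 3 values shown sits. Compound 3 `CC(C)n1c(/C=C2/C(=O)Nc3ccc(Cl)cc32)nc2ccccc21` differs from compound 1 by chloro in place of bromo on an aromatic carbon, and in this assay compound 3 gives 35700 nM; the step was a 6.0-fold higher number from compound 1 to compound 3 (0.78 log units; beyond the scatter).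

Compound 4 `Cn1c(/C=C2/C(=O)Nc3ccc(Cl)cc32)nc2ccccc21` has not been measured in this assay. It stands to compound 3 as compound 2 stands to compound 1: the change is methyl in place of isopropyl on an aromatic nitrogen, the same change already seen, with the same surroundings at the place of the change. The two cores, that of compound 3 and that of compound 1, differ only by chloro in place of bromo on an aromatic carbon.

Since compound 3 already gives 35700 nM, and the same change took compound 1 to the limit with an at least 8.3-fold higher number from compound 1 to compound 2 (0.92 log units; beyond the scatter), compound 4 is expected to show a 5.6-fold higher number from compound 3 to compound 4 (0.75 log units; beyond the scatter) in this assay. Compound 4 is therefore estimated at about 200000 nM, most likely reported only as a limit, with a range from 50000 nM to 800000 nM.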

Compound 4, half-maximal inhibitory concentration: 43600 nM
Compound 4: middle estimate off by 4.6-fold (0.66 log units), on the high side, outside the stated range (below it).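

In this assay, methyl in place of isopropyl did not carry over from the bromo core to the chloro core at the same size, since the step on the chloro core was a 1.2-fold higher number from compound 3 to compound 4 (0.09 log units; within the scatter), and the two steps differ: the same change on two cores in this assay, an at least 8.3-fold higher number (0.92 log units; beyond the scatter) from compound 1 to compound 2 and a 1.2-fold higher number (0.09 log units; within the scatter) from compound 3 to compound 4, at least 6.8-fold (0.83 log units) apart, beyond the scatter of two such steps Read the other way, chloro in place of bromo also depended on the group on the aromatic nitrogen, giving an at least 1.1-fold lower number from compound 2 to compound 4 (0.05 log units; that floor lies within the scatter) with methyl there, against a clear step with isopropyl there: the same change on two cores in this assay, a 6.0-fold higher number (0.78 log units; beyond the scatter) from compound 1 to compound 3 and an at least 1.1-fold lower number (0.05 log units; that floor lies within the scatter) from compound 2 to compound 4, at least 6.8-fold (0.83 log units) apart, beyond the scatter of two such steps What this does not show is the true size of either gap or any reason for it, and it gives no rule beyond these two cores, as compound 2 gives a limit of the assay and not a number: the limit of > 50000 nM in this assay, at which 1 of the 4 values shown sits.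

The compounds shown leave open how an ethyl group, a longer chain or a chain ending in an amine on the aromatic nitrogen would behave on the bromo and chloro cores. They also leave open whether fluoro or methoxy in place of bromo on the aromatic carbon would depend in the same way on the group on that nitrogen.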